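One aromatic substituent exchanged: compound 3 to compound 4

This account rests on a few compounds, and the source may have more. Where it says the series, first, only, none or still open, it means among the compounds named here.

Measured in an ADME assay (liver) for metabolic stability, with Liver microsome (Homo sapiens) as the target, using microsomes and NADPH, with a stated time of 30 min, tested at 1 uM; a higher number here means faster removal of the compound, a lower number slower removal:
Compound 1 `COc1cc(C(O)(C(F)(F)F)C(F)(F)F)cnc1N1CCN(S(=O)(=O)c2ccc(N)nc2)CC1`: < 14 mL.min-1.g-1 (a limit of the assay)
Compound 2 `CCn1cc(-c2cc(C(O)(C(F)(F)F)C(F)(F)F)cnc2N2CCN(S(=O)(=O)c3ccc(N)nc3)CC2)cn1`: 20 mL.min-1.g-1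
Compound 3 `Nc1ccc(S(=O)(=O)N2CCN(c3ncc(C(O)(C(F)(F)F)C(F)(F)F)cc3-c3cnccc3F)CC2)cn1`: 17 mL.min-1.g-1

The entry for compound 1 is a limit and not a number. Compound 3 stands within the scatter of its nearest neighbour: a 1.2-fold lower number from compound 2 to compound 3 (0.07 log units; within the scatter). In compound 4 `Cc1nc2cc(-c3cc(C(O)(C(F)(F)F)C(F)(F)F)cnc3N3CCN(S(=O)(=O)c4ccc(N)nc4)CC3)ccc2o1`, 2-methyl-1,3-benzoxazol-5-yl stands in place of 4-fluoropyridin-3-yl on an aromatic carbon (2-methyl-1,3-benzoxazol-5-yl in place of 4-fluoropyridin-3-yl on an aromatic carbon).

Among the measured compounds shown here, the closest precedent is the exchange of one aromatic group for another already seen between compound 2 and compound 3, which stayed within the scatter. The two steps away from methoxy are an at least 1.4-fold higher number from compound 1 to compound 2 (0.15 log units; that floor lies within the scatter) and an at least 1.2-fold higher number from compound 1 to compound 3 (0.08 log units; that floor lies within the scatter). Both floors lie within the scatter and rest on (the limit of < 14 mL.min-1.g-1 in this assay, at which 1 of the 3 values shown sits). None of these steps introduces the new group, so the estimate stays wide. No step beyond the scatter is expected in this assay, with only a slight upward lean. The expected change is a 1.3-fold higher number from compound 3 to compound 4 (0.11 log units; within the scatter). Compound 4 is estimated at 22 mL.min-1.g-1, within an expected range of 12 mL.min-1.g-1 to 40 mL.min-1.g-1.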

Compound 4, intrinsic clearance in microsomes: < 14 mL.min-1.g-1
Compound 4 gave a limit, no number; the forecaster's own chance of this, stated with the estimate: 15%; middle value at least 1.5-fold (0.19 log units) away from the limit.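

In this assay, compound 4, whose new group carries one five-membered and one six-membered aromatic ring, gives a limit and not a number. The position therefore accepts this larger aromatic group without any measured rise in the read-out, although the steps, an at least 1.2-fold lower number from compound 3 to compound 4 (0.08 log units; that floor lies within the scatter) and an at least 1.4-fold lower number from compound 2 to compound 4 (0.15 log units; that floor lies within the scatter), do not establish a real fall. The step from compound 1 to compound 4 cannot be read, and the series now has a second compound at the same limit: the limit of < 14 mL.min-1.g-1 in this assay, at which 2 of the 4 values shown sit.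

Going by these compounds, how far compound 1 and compound 4 actually lie under that limit remains unknown. Also open, on these data alone, is whether an amine such as morpholine, or a carboxylic acid, on this aromatic carbon would stay at the limit in this assay.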